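Moving the Ring Nitrogen on a Shared Core

A few compounds are considered here, and "the series" means these few. Any claim that something is new, unique, unknown or untested is made for them only; others in the source may bear on it.

Three compounds on a shared core were tested in a functional assay on T47D cells (Homo sapiens) for cytotoxicity, read by CCK-8 assay; on this read-out higher numbers stand for weaker inhibition and lower numbers for stronger inhibition. Compound 1 `Oc1cccc(-c2cc(-c3ccsc3)cc(-c3ccccc3O)n2)c1` sits at the assay limit, > 50000 nM. Compound 2 `Oc1cccc(-c2cc(-c3ccco3)cc(-c3ccccc3O)n2)c1` gives 820 nM, and compound 3 `Oc1cccc(-c2cc(-c3ccccn3)cc(-c3ccccc3O)n2)c1` gives 2560 nM. Of the two numbers shown, compound 3 stands highest, with compound 2 nearest and lower; that step is a 3.1-fold higher number from compound 2 to compound 3 (0.49 log units; beyond the scatter). The moves away from compound 1 are larger, an at least 60-fold lower number from compound 1 to compound 2 (1.78 log units; beyond the scatter) and an at least 19-fold lower number from compound 1 to compound 3 (1.29 log units; beyond the scatter), though both start from a limit.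

Compound 4 `Oc1cccc(-c2cc(-c3cccnc3)cc(-c3ccccc3O)n2)c1` differs from compound 3 by pyridin-3-yl in place of pyridin-2-yl on an aromatic carbon; the two have the same atoms, joined differently. Among the compounds with values here, no measured step exchanges pyridin-2-yl for pyridin-3-yl. The nearest guide is the exchange of furan-2-yl for pyridin-2-yl, a 3.1-fold higher number from compound 2 to compound 3 (0.49 log units; beyond the scatter), which was modest, while the exchanges starting from thiophen-3-yl were large. None of them kept the same ring and moved only the nitrogen. For compound 4 a step within the usual scatter is therefore expected, a 1.0-fold lower number from compound 3 to compound 4 (0.01 log units; within the scatter). Compound 4 is estimated at 2500 nM in this assay, with a range from 800 nM to 8000 nM.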

Compound 4, half-maximal inhibitory concentration: 6230 nM
Beside the measured number, compound 4's estimate is 2.5-fold (0.40 log units) below it; measured number inside the range.
By their numbers in this assay, from the lowest: compound 2; then compound 3; then compound 4. At a limit, above all of these: compound 1.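

Within the data shown here, exchanging pyridin-2-yl for pyridin-3-yl, at the position opposite the ring nitrogen of the shared core, is the first step here that keeps the same ring and moves only its nitrogen, and that move alone changes the result: a 2.4-fold higher number from compound 3 to compound 4 (0.39 log units; beyond the scatter). Pyridin-3-yl also falls further from furan-2-yl than pyridin-2-yl does, with a 7.6-fold higher number from compound 2 to compound 4 (0.88 log units; beyond the scatter), so the place of the nitrogen matters at this position as well as the kind of ring. The step of an at least 8.0-fold lower number from compound 1 to compound 4 (0.90 log units; beyond the scatter) is the smallest of those away from compound 1, and it starts from a limit: the limit of > 50000 nM in this assay, at which 1 of the 4 values shown sits.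

From the compounds shown here alone, how pyridin-4-yl or plain phenyl would fall in this order remains open. So does the reading of the thiophen-3-yl and furan-2-yl gap, which thiophen-2-yl or furan-3-yl would help to separate into ring atom and attachment point.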